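From Methoxy to Acetamido: Compound 3 to Compound 4

This account rests on a few compounds, and the source may have more. Where it says the series, first, only, none or still open, it means among the compounds named here.

In an ADME assay on HeLa cells (Homo sapiens) for cytotoxicity, read by crystal violet staining, with a stated time of 72 h (on this read-out higher numbers stand for lower toxicity in this test and lower numbers for higher toxicity in this test), compound 1 (`CCOC(=O)c1cc(CCCOc2ccc(-c3noc(C(F)(F)F)n3)cc2OC)on1`) gives > 100000 nM, which is a limit of the assay and not a number. Compound 2 (`CCNC(=O)c1cc(CCCOc2c(C)cc(-c3noc(C(F)(F)F)n3)cc2C)on1`) gives > 100000 nM, again a limit. Within the data shown here, compound 3 (`COc1cc(-c2noc(C(F)(F)F)n2)ccc1OCCCc1cc(C(=O)N(C)C)no1`) gives 68000 nM, the only actual number so far. The two limits are the same one: the limit of > 100000 nM in this assay, at which 2 of the 3 values shown sit.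

The next structure is compound 4 (`CC(=O)Nc1cc(-c2noc(C(F)(F)F)n2)ccc1OCCCc1cc(C(=O)N(C)C)no1`), and the change leading to it is acetamido in place of methoxy on an aromatic carbon. Acetamido replaces methoxy on an aromatic carbon, ortho to a large group.

Among the measured compounds shown here, the only measured step is an at least 1.4-fold lower number from compound 1 to compound 3 (0.16 log units; that floor lies within the scatter). It concerns a carbonyl carbon rather than this aromatic carbon, so it gives no guide to direction, and no step beyond the scatter is expected in this assay. The expected change is small, an estimated 1.0-fold higher number from compound 3 to compound 4 (0.01 log units; within the scatter). The estimate for compound 4 is 70000 nM, with an expected range from 30000 nM to 100000 nM.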

Compound 4, half-maximal cytotoxic concentration: > 100000 nM
Compound 4 gave a limit, no number (the forecaster's own chance of this, stated with the estimate: 35%); middle value at least 1.4-fold (0.15 log units) away from the limit.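

In this assay, putting acetamido in place of methoxy on this aromatic carbon gives an at least 1.4-fold higher number from compound 3 to compound 4 (0.16 log units; that floor lies within the scatter). This is the first step shown at this position, and it shows that a larger group carrying a hydrogen-bond donor brings no lower number here. The result for compound 4 is a limit of the assay and not a number, so the full size of the step cannot be read, and compound 4 now sits with most of the series at one shared limit: the limit of > 100000 nM in this assay, at which 3 of the 4 values shown sit.

Compound 3 alone carries an actual number, so the compounds shown give little sense of what separates a lower number from this limit. Going by these compounds, whether a primary amine or a carboxylic acid on this aromatic carbon would also reach the limit remains open.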